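The compounds below may be only part of what the source reports. "The series", "measured", "known", "first", "only" and "open" are said of these compounds alone.

Compound 1, `CS(=O)(=O)Nc1ccc(NC(=O)c2cccc(C(F)(F)F)c2)cc1Cl`, in an ADME assay on RAW264.7 cells (Mus musculus) for cytotoxicity, read by MTT assay, with a stated time of 48 h; a higher number here means a weaker inhibitor, a lower number a stronger inhibitor: compound 1 gives > 250000 nM, which is a limit of the assay and not a number.
Compound 2, `CS(=O)(=O)Nc1ccc(NC(=O)c2cc(C(F)(F)F)cc(C(F)(F)F)c2)cc1Cl`: compound 2 gives 69600 nM.
Compound 3, `O=C(Nc1ccc(NS(=O)(=O)C(F)(F)F)c(F)c1)c1cccc(C(F)(F)F)c1`: compound 3 gives 34400 nM.

Compound 1 and compound 2 share one core and differ in a single place: trifluoromethyl in place of hydrogen on an aromatic carbon. This change brings an at least 3.5-fold lower number from compound 1 to compound 2 (0.55 log units; beyond the scatter). The size of that step is known only as a bound because of the limit of > 250000 nM in this assay, at which 1 of the 3 values shown sits.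

How the core of compound 3 differs from the core of compound 1 is not broken down here. Among the two numbers given, compound 3 stands lower than compound 2, and the gap between them lies beyond the usual scatter.

Compound 4, `O=C(Nc1ccc(NS(=O)(=O)C(F)(F)F)c(F)c1)c1cc(C(F)(F)F)cc(C(F)(F)F)c1`, is not yet measured. It differs from compound 3 by trifluoromethyl in place of hydrogen on an aromatic carbon. This is the same change as from compound 1 to compound 2, and the surroundings of the place are described in the same words for both pairs. For compound 4 in this assay, a step of similar direction is expected, a 2.9-fold lower number from compound 3 to compound 4 (0.46 log units; beyond the scatter), which rests on the step of an at least 3.5-fold lower number from compound 1 to compound 2 (0.55 log units; beyond the scatter) seen for the measured pair. On that basis compound 4 is estimated at 12000 nM, with the expected range running from 5000 nM to 30000 nM.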

Compound 4, half-maximal inhibitory concentration: 112000 nM
The estimate for compound 4 lay 9.3-fold (0.97 log units) below the measured number; the whole stated range lies below it.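

In this assay, trifluoromethyl in place of hydrogen on an aromatic carbon brings a 3.3-fold higher number from compound 3 to compound 4 (0.51 log units; beyond the scatter), so the step seen on the core of compound 1 did not carry over to the core of compound 3, and the two steps run in opposite directions: the same change on two cores in this assay, an at least 3.5-fold lower number (0.55 log units; beyond the scatter) from compound 1 to compound 2 and a 3.3-fold higher number (0.51 log units; beyond the scatter) from compound 3 to compound 4, at least 11-fold (1.06 log units) apart, beyond the scatter of two such steps. The step on the core of compound 1 is known only as a bound, and the value of compound 1 is a limit of the assay and not a number: the limit of > 250000 nM in this assay, at which 1 of the 4 values shown sits. The result shows that, in this series, the direction of this change cannot be assumed to hold from one core to the other, but with a single pair on each core it does not show why the direction reverses or which feature of the cores goes with the reversal.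

As far as these compounds go, compounds 1 and 2 pair chlorine with a methanesulfonyl group, while compounds 3 and 4 pair fluorine with a trifluoromethanesulfonyl group, so it stays open which of these two differences, or whether both together, goes with the reversal. Also open, from the compounds shown here alone, is how a nitrile or a carboxylic acid at the place of the added trifluoromethyl would read in this assay on either core.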